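The source may hold more compounds than are shown below. What is called first, only, known or untested is meant among the compounds shown, and "the series" means these compounds.

Three compounds built on a shared core were tested in a functional assay on A549 cells (Homo sapiens) for cytotoxicity, read by trypan blue exclusion, with a stated time of 48 h (on this read-out lower numbers stand for stronger inhibition and higher numbers for weaker inhibition), where compound 1 `Cc1ccc(-c2csc(NC(=O)COc3ccc(Cl)c(C)c3)n2)cc1` gives 44500 nM. In this assay compound 2 `Cc1cc(OCC(=O)Nc2nc(-c3ccc(Br)cc3)cs2)ccc1Cl` gives 51700 nM, and compound 3 `O=C(COc1ccc(F)cc1)Nc1nc(-c2ccc(Br)cc2)cs1` gives 51700 nM. Compound 1 differs from compound 2 by methyl in place of bromo on an aromatic carbon, a change that made a 1.2-fold lower number from compound 2 to compound 1 (0.07 log units; within the scatter). The cores of compound 2 and compound 3 differ by 4-fluorophenyl in place of 4-chloro-3-methylphenyl on an oxygen on a saturated carbon, with no change at the digits printed from compound 2 to compound 3 (within the scatter).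

Compound 4 `Cc1ccc(-c2csc(NC(=O)COc3ccc(F)cc3)n2)cc1` is not yet measured. Within the data shown here, it differs from compound 3 by methyl in place of bromo on an aromatic carbon, the same change as the one between compound 2 and compound 1, at the same place. A step of the same small size is expected here, a 1.2-fold lower number from compound 3 to compound 4 (0.07 log units; within the scatter), because the earlier one was a 1.2-fold lower number from compound 2 to compound 1 (0.07 log units; within the scatter). Compound 4 is therefore estimated at 44000 nM in this assay, with a range from 25000 nM to 85000 nM.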

Compound 4, half-maximal inhibitory concentration: 19100 nM
Estimate against measurement, compound 4: 2.3-fold (0.36 log units) above, outside the stated range (below it).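

In this assay, methyl in place of bromo gives a 2.7-fold lower number from compound 3 to compound 4 (0.43 log units; beyond the scatter), and 4-fluorophenyl in place of 4-chloro-3-methylphenyl gives a 2.3-fold lower number from compound 1 to compound 4 (0.37 log units; beyond the scatter). The methyl change may therefore carry over from one core to the other, but a real difference between the cores is neither shown nor ruled out: the same change on two cores in this assay, a 1.2-fold lower number (0.07 log units; within the scatter) from compound 2 to compound 1 and a 2.7-fold lower number (0.43 log units; beyond the scatter) from compound 3 to compound 4, 2.3-fold (0.37 log units) apart, within the scatter of two such steps. The same holds for the 4-fluorophenyl change, and two pairs of compounds give no rule for other cores: the same change on two cores in this assay, no change at the digits printed (within the scatter) from compound 2 to compound 3 and a 2.3-fold lower number (0.37 log units; beyond the scatter) from compound 1 to compound 4, 2.3-fold (0.37 log units) apart, within the scatter of two such steps.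

Still open, from the compounds shown here alone, is how an amine or a carboxylic acid in place of the bromo would read in this assay. Also open, going by these compounds, is whether a longer chain in place of the methyl would follow the same steps on both cores.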